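The source may report more compounds than this note shows. Statements on the series, on what has been measured and on what is new or still open speak of the compounds shown alone.

Measured so far in an assay on COS-7 cells for inhibition of sodium/nucleoside cotransporter 2 (Homo sapiens), read by scintillation counting, in the presence of a further agent that is not named here; a lower number here means a stronger inhibitor, a higher number a weaker inhibitor:
compound 1, `CCOC(=O)OC[C@H]1O[C@@H](n2cnc3c(N)ncnc32)[C@H](O)[C@@H]1O`: > 100000 nM
compound 2, `Nc1ncnc2c1nc(NCc1cccc(-c3ccccc3)c1)n2[C@@H]1O[C@H](CO)[C@@H](O)[C@H]1O`: 21000 nM
compound 3, `Nc1ncnc2c1nc(NCc1ccc(-c3ccccc3)cc1)n2[C@@H]1O[C@H](CO)[C@@H](O)[C@H]1O`: 640 nM

Compound 1 stands at a limit of this assay, not at a number (the limit of > 100000 nM in this assay, at which 1 of the 3 values shown sits). Of the two numbers shown, compound 3 has the lowest; the nearest, compound 2, sits well beyond the scatter from it. Compound 4, `Nc1ncnc2c1nc(NCc1ccc(Cl)cc1)n2[C@@H]1O[C@H](CO)[C@@H](O)[C@H]1O`, differs from compound 3 by chloro in place of phenyl on an aromatic carbon. Among the compounds with values here, no step between measured compounds carries this change, so the expectation rests on compound 3 alone. In this assay a step of moderate size toward a higher number is expected, a 4.7-fold higher number from compound 3 to compound 4 (0.67 log units; beyond the scatter), with wide uncertainty. Compound 4 is expected to give 3000 nM, within 800 nM to 15000 nM.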

Compound 4, half-maximal inhibitory concentration: 11000 nM
The estimate for compound 4 lay 3.7-fold (0.56 log units) below the measured number; low and high end bracket the measured number.
By their numbers in this assay, from the lowest: compound 3; then compounds 4 and 2 (each within the scatter of the next). At a limit, above all of these: compound 1.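

In this assay, chloro in place of phenyl on an aromatic carbon, para to a large group, gives a 17-fold higher number from compound 3 to compound 4 (1.24 log units; beyond the scatter), the first step read at this position. The number here therefore depends strongly on the group this carbon carries, and of the two groups compared, phenyl gives the lower number. Nothing measured here bears on the cause of this step. Still open, from the compounds shown here alone, is how other groups at this position would compare with phenyl and chloro, such as a cyclohexyl ring, a pyridine ring, a methoxy group, an amine or a carboxylic acid. Also open, going by these compounds, is whether the same step would appear with the phenyl on the benzyl ring of compound 2.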